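From 2,2,2-trifluoroethoxy to isobutylsulfanyl on the shared core

A few compounds are considered here, and "the series" means these few. Any claim that something is new, unique, unknown or untested is made for them only; others in the source may bear on it.

Measured in an ADME assay on BCBL1 cells (Homo sapiens) for cytotoxicity, with a stated time of 7 days; on this read-out higher numbers stand for lower toxicity in this test and lower numbers for higher toxicity in this test:
Compound 1 `CNc1nc(N)nc2c1ncn2/C=C1/CC1(CO)CO`: 67000 nM
Compound 2 `Nc1nc(OCC(F)(F)F)c2ncn(/C=C3/CC3(CO)CO)c2n1`: > 20000 nM

Compound 2 stands at the limit of > 20000 nM in this assay, at which 1 of the 2 values shown sits, which is a limit and not a number. Going by these compounds, its exact place on the scale therefore remains open.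

Compound 3 `CC(C)CSc1nc(N)nc2c1ncn2/C=C1/CC1(CO)CO` has not yet been measured. It carries isobutylsulfanyl in place of the 2,2,2-trifluoroethoxy of compound 2, on the same aromatic carbon: isobutylsulfanyl in place of 2,2,2-trifluoroethoxy on an aromatic carbon.

Among the measured compounds shown here, one measured step bears on this carbon: a step that the limit leaves unreadable from compound 1 to compound 2. Its size cannot be read, so it offers neither a size nor a direction to carry over. No step beyond the usual scatter is therefore expected in this assay, though the margin is wide. The estimated change is a step that the limit leaves unreadable from compound 2 to compound 3.

The expected value for compound 3 is 30000 nM, with an estimated range from 8000 nM to 100000 nM.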

Compound 3, half-maximal cytotoxic concentration: > 20000 nM
Compound 3: only a limit was reported; the forecaster's own chance of this, stated with the estimate: 50%; the middle value lies beyond the limit too.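

No new step can be read among compound 1, compound 2 and compound 3, because the values of compound 2 and compound 3 are limits and not numbers: the limit of > 20000 nM in this assay, at which 2 of the 3 values shown sit. The compounds shown leave open where compound 2 and compound 3 actually lie in this assay, and so whether isobutylsulfanyl differs there from 2,2,2-trifluoroethoxy or methylamino.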